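The source may report more compounds than this note shows. Statements on the series, on what has been measured and on what is new or still open speak of the compounds shown alone.

Working notes on the series. Among the measured compounds shown here, compound 1 `Cc1sc2nc(NC(=O)CCCc3ccccc3)sc(=O)c2c1C` is the one member with a numeric reading: in an in vitro assay on cells for inhibition of Amine oxidase [flavin-containing] B (Homo sapiens), read by fluorescence and Amplex Red, with stated times of 30 min and 45 min (on this read-out lower numbers stand for stronger inhibition and higher numbers for weaker inhibition), compound 1 gives 9.8 nM. Compound 2 `O=C(C/C=C/c1cccc(Cl)c1)Nc1nc2ccccc2c(=O)s1` stands apart. In this assay compound 2 gives only a limit, > 1000 nM, and not a number. Of the two values shown, compound 2 is the one that sits at the limit of > 1000 nM in this assay, at which 1 of the 2 values shown sits. For the measured compounds named here, no step between measured compounds differing in one place is available, so no measured change can be called on here.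

Compound 3 `O=C(C/C=C/c1ccc(Cl)c(Cl)c1)Nc1nc2ccccc2c(=O)s1` is not yet measured. It differs from compound 2 as follows: chloro in place of hydrogen on an aromatic carbon, which read one bond further out is 3-chlorophenyl to 3,4-dichlorophenyl. Because compound 2 gives > 1000 nM as a limit, the step to compound 3 in this assay can only be set by expectation; a small gain toward stronger inhibition, or nothing beyond the scatter, is the working assumption. The expected step is a step that the limit leaves unreadable from compound 2 to compound 3. Compound 3 is thus expected at 1500 nM, within a range from 400 nM to 6000 nM, and a limit reading rather than a number remains the likelier outcome.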

Compound 3, half-maximal inhibitory concentration: > 10000 nM
Compound 3: no number, only a limit (the forecaster's own chance of this, stated with the estimate: 70%); at least 6.6-fold (0.82 log units) between middle value and limit.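

In this assay compound 3 gives only a limit, > 10000 nM, not a number. Among the compounds shown here, compound 2 likewise gives only a limit, > 1000 nM, so no step from compound 2 to compound 3 can be read. The compounds shown leave open whether chloro in place of hydrogen on this aromatic carbon changes inhibition at all, and by how much.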